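Methoxyphenyl Swap on a Core Where Every Value Is a Limit

The compounds below may be only part of what the source reports. "The series", "measured", "known", "first", "only" and "open" are said of these compounds alone.

Compound 1 `Cc1cc(Cc2ccc(C(F)(F)F)cc2)c(=O)n(CC(=O)Nc2ccc(Br)cc2)n1` in an assay on HL-60 cells for agonist activity at N-formyl peptide receptor 3 (Homo sapiens), read by calcium flux (a higher number here means that more compound is needed for the effect, a lower number that less compound is needed), gives > 50000 nM, which is a limit of the assay rather than a number.
Compound 2 `Cc1cc(Cc2ccoc2)c(=O)n(CC(=O)Nc2ccc(Br)cc2)n1` gives > 50000 nM, also a limit.
Compound 3 `Cc1cc(Cc2cccc3ccccc23)c(=O)n(CC(=O)Nc2ccc(Br)cc2)n1` gives > 50000 nM, again a limit.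

Compound 2 therefore stands at the limit, and so do the other two measured compounds, because of the limit of > 50000 nM in this assay, at which 3 of the 3 values shown sit. The change to compound 4 `COc1ccc(-c2cc(C)nn(CC(=O)Nc3ccc(Br)cc3)c2=O)cc1` is 4-methoxyphenyl in place of (furan-3-yl)methyl on an aromatic carbon. The measured steps at that same position are a step that the two limits leave unreadable from compound 1 to compound 2, a step that the two limits leave unreadable from compound 1 to compound 3 and a step that the two limits leave unreadable from compound 2 to compound 3; none of them can be read, so they point in no direction. Compound 4 is expected to sit at the limit too, with an estimated 50000 nM and a range from 10000 nM to 200000 nM. The expected step is a number no higher from compound 2 to compound 4 (the limit leaves the size open), nothing beyond the scatter.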

Compound 4, half-maximal effective concentration: > 50000 nM
Compound 4 ended at the assay's limit; the forecaster's own chance of this, stated with the estimate: 80%; the middle value lies on the limit itself.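

Going by these compounds alone, compound 2 and compound 4 both stand at a limit of the assay, and no step between them can be read. The compounds shown leave open whether 4-methoxyphenyl and (furan-3-yl)methyl differ at all in their effect.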